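Swapping an arylthio group for piperidinyl at the exchanger core

The source may hold more compounds than are shown below. What is called first, only, known or untested is meant among the compounds shown, and "the series" means these compounds.

The measured compounds and their values:
compound 1, `CCc1cc(C)c(C(=O)N=C(N)N)cc1S(C)(=O)=O`, 4.8 nM
compound 2, `CCCSc1cc(C)c(C(=O)N=C(N)N)cc1S(C)(=O)=O`, 6.8 nM
compound 3, `Cc1cc(Sc2ccc(Cl)cc2)c(S(C)(=O)=O)cc1C(=O)N=C(N)N`, 19 nM

In a functional assay for inhibition of sodium/hydrogen exchanger (Oryctolagus cuniculus) (a lower number here means a stronger inhibitor, a higher number a weaker inhibitor), compound 3 gives 19 nM, the highest number of the three. Its nearest neighbour is compound 2, reached by a 2.8-fold higher number from compound 2 to compound 3 (0.45 log units; beyond the scatter), and the furthest is compound 1, reached by a 4.0-fold higher number from compound 1 to compound 3 (0.60 log units; beyond the scatter). Compound 1 and compound 2 differ from each other only by a 1.4-fold higher number from compound 1 to compound 2 (0.15 log units; within the scatter).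

The unmeasured compound 4, `Cc1cc(N2CCCCC2)c(S(C)(=O)=O)cc1C(=O)N=C(N)N`, is reached from compound 3 by one change: piperidin-1-yl in place of (4-chlorophenyl)sulfanyl on an aromatic carbon.

No measured step exchanges a (4-chlorophenyl)sulfanyl group for piperidin-1-yl, so nothing shown bears on this change directly. What the measured steps do show is that the group at this aromatic carbon differs among the measured compounds, and in every step the number in this assay moved only modestly: the two beyond-scatter steps, from compound 1 and from compound 2 to compound 3, are both modest, and the remaining one lies within the scatter. A similarly modest step is therefore expected for compound 4 in this assay, and, since compound 3 already holds the highest number and compound 1 and compound 2, which carry smaller groups at that carbon, sit below it, the expected direction is toward a somewhat lower number, a 1.9-fold lower number from compound 3 to compound 4 (0.28 log units; within the scatter). The estimate for compound 4 in this assay is 10 nM, expected between 3.5 nM and 30 nM.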

Compound 4, half-maximal inhibitory concentration: 21 nM
Compound 4: the middle estimate sits 2.1-fold (0.32 log units) below what was measured; low and high end bracket the measured number.
By their numbers in this assay, from the lowest: compounds 1 and 2 (each within the scatter of the next); then compounds 3 and 4 (each within the scatter of the next).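

In this assay, the exchange of (4-chlorophenyl)sulfanyl for piperidin-1-yl on this aromatic carbon, ortho to a methylsulfonyl group, gives a 1.1-fold higher number from compound 3 to compound 4 (0.04 log units; within the scatter), so this position carries either a sulfur-linked aromatic ring or a nitrogen-linked non-aromatic ring with no readable difference between them. Set against the two compounds without a ring in this group, piperidin-1-yl gives a 3.1-fold higher number from compound 2 to compound 4 (0.49 log units; beyond the scatter) and a 4.4-fold higher number from compound 1 to compound 4 (0.64 log units; beyond the scatter), which places compound 4 with compound 3 above the ethyl and propylsulfanyl compounds, and none of the four compounds goes against this split. No measurement at hand explains the split or the match between the two ring-bearing groups.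

The compounds leave open whether the ring itself sets this level, since a straight chain longer than propylsulfanyl, an open-chain amine such as dimethylamino or an unsubstituted phenylsulfanyl group could fall on either side of the split. They also leave open how a second hetero atom in the ring, as in morpholine or piperazine, or a carboxylic acid at this carbon would read in this assay.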